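This account rests on a few compounds, and the source may have more. Where it says the series, first, only, none or still open, it means among the compounds named here.

Measured in a functional assay on HeLa cells (Homo sapiens) for inhibition, read by MTT assay, with a stated time of 72 h; on this read-out higher numbers stand for weaker inhibition and lower numbers for stronger inhibition:
- compound 1 `Nc1ncnc2c1c(-c1cnc3[nH]ccc3c1)nn2CC(=O)NO`: "not determined" (no result reported)
- compound 2 `Nc1ncnc2c1c(-c1cnc3[nH]ccc3c1)nn2CCCCCC(=O)NO`: > 150000 nM (a limit, not a number)

Compound 2 stands only at a limit, with no exact number: the limit of > 150000 nM in this assay, at which 1 of the 2 values shown sits. Compound 3 `Nc1ncnc2c1c(-c1cnc3[nH]ccc3c1)nn2CCCCCCC(=O)NO` differs from compound 2 by one change: (hydroxycarbamoyl)methyl in place of hydroxycarbamoyl on a saturated chain carbon, five bonds along the chain from an aromatic nitrogen. This places (hydroxycarbamoyl)methyl in place of hydroxycarbamoyl on a saturated chain carbon, five bonds along the chain from an aromatic nitrogen. For the measured compounds named here, no measured step is available as a guide, so no change beyond the scatter is expected in this assay. The expected step is an at least 1.2-fold lower number from compound 2 to compound 3 (0.09 log units; that floor lies within the scatter). Compound 3 is estimated at 120000 nM, with an expected range of 30000 nM to 200000 nM.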

Compound 3, half-maximal inhibitory concentration: 22000 nM
Compound 3: middle estimate off by 5.5-fold (0.74 log units), on the high side; the whole stated range lies above it.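

In this assay, the single added chain carbon, with (hydroxycarbamoyl)methyl in place of hydroxycarbamoyl, gives an at least 6.8-fold lower number from compound 2 to compound 3 (0.83 log units; beyond the scatter). This shows that the number at this place on the chain responds to chain length, and compound 3 holds the only exact value among the compounds shown. The size of the step is only a floor, because compound 2 stands at a limit and not at a number: the limit of > 150000 nM in this assay, at which 1 of the 3 values shown sits.

Open, going by these compounds, is whether a longer chain would lower the number further. Also open, on these data alone, is whether a carboxylic acid at the chain end would give a similar number to the hydroxycarbamoyl group.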